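Amide-side ester variation in a cytotoxicity series

This account rests on a few compounds, and the source may have more. Where it says the series, first, only, none or still open, it means among the compounds named here.

Measured compounds:
compound 1, `COC(=O)[C@H](NC(=O)Cn1cc(C2=C(c3c[nH]c4ccccc34)C(=O)N(C)C2=O)c2ccccc21)[C@@H](C)O`: 23400 nM
compound 2, `COC(=O)CCNC(=O)Cn1cc(C2=C(c3c[nH]c4ccccc34)C(=O)N(C)C2=O)c2ccccc21`: 50900 nM

Within the data shown here, in a functional assay on HCT-8 cells (Homo sapiens) for cytotoxicity, read by MTT assay, with a stated time of 24 h (a lower number here means a stronger inhibitor, a higher number a weaker inhibitor), compound 2 gives the highest of the two numbers; its only neighbour is compound 1, and the step of a 2.2-fold higher number from compound 1 to compound 2 (0.34 log units; beyond the scatter) is modest but beyond the scatter. Compound 3, `COC(=O)[C@H](NC(=O)Cn1cc(C2=C(c3c[nH]c4ccccc34)C(=O)N(C)C2=O)c2ccccc21)C(C)C`, differs from compound 2 by 1-(methoxycarbonyl)-2-methylpropyl in place of 2-(methoxycarbonyl)ethyl on an amide-type nitrogen. Among the measured compounds shown here, the single step that bears on this change is a 2.2-fold higher number from compound 1 to compound 2 (0.34 log units; beyond the scatter), which also exchanged a 1-(methoxycarbonyl)alkyl group for the 2-(methoxycarbonyl)ethyl chain; compound 3 returns to a 1-(methoxycarbonyl)alkyl pattern, so a modest lower number is expected, roughly back toward compound 1. The expected step is a 2.0-fold lower number from compound 2 to compound 3 (0.29 log units; within the scatter). For compound 3 the expected value is 26000 nM, within 11000 nM to 60000 nM.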

Compound 3, half-maximal inhibitory concentration: 25800 nM
The estimate for compound 3 lay 1.0-fold (0.00 log units) above the measured number; the range from low to high includes it.
By their numbers in this assay, from the lowest: compounds 1, 3 and 2 (each within the scatter of the next, the first and the last beyond it).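

In this assay isopropyl in place of 1-hydroxyethyl on the saturated chain carbon gives no separation between the two side chains (a 1.1-fold higher number from compound 1 to compound 3 (0.04 log units; within the scatter)), so the hydroxyl of compound 1 is not required for its value. 1-(Methoxycarbonyl)-2-methylpropyl in place of 2-(methoxycarbonyl)ethyl also stays within the scatter (a 2.0-fold lower number from compound 2 to compound 3 (0.30 log units; within the scatter)), so only compound 1 and compound 2 are separated. No supporting data explain these numbers.

Still open, from the compounds shown here alone, is whether a carboxylic acid in place of the methyl ester, or an amine on the side chain, would shift the number beyond the scatter.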